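A few compounds are considered here, and "the series" means these few. Any claim that something is new, unique, unknown or untested is made for them only; others in the source may bear on it.

Working notes on the series, read in a functional assay on MDA-MB-231 cells (Homo sapiens) for inhibition, read by CCK-8 assay, with a stated time of 48 h; a lower number here means a stronger inhibitor of growth, a higher number a weaker inhibitor of growth. Compound 1 `Cc1ccccc1Nc1nc(NC2CC2)ncc1Cl` returns only a limit of the assay, > 100000 nM, and not a number. Compound 2 `Cc1ccccc1Nc1nc(Nc2ccc(N3CCN(C)CC3)cn2)ncc1Cl` gives 7470 nM. Compound 3 `CN1CCN(c2ccc(Nc3ncc(Cl)c(Nc4ccccc4)n3)nc2)CC1` gives 37400 nM, the higher of the two numbers in the series.

Compound 4 `CN1CCN(c2ccc(Nc3ncc(Cl)c(NCc4ccccc4)n3)nc2)CC1` is not yet measured. It differs from compound 3 as follows: benzyl in place of phenyl on a nitrogen on an aromatic ring. In words, this is benzyl in place of phenyl on a nitrogen on an aromatic ring, or anilino to benzylamino.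

Among the compounds with values here, one measured step bears on this group: a 5.0-fold higher number from compound 2 to compound 3 (0.70 log units; beyond the scatter), with hydrogen in place of methyl on an aromatic carbon. That step was modest and it does not test the anilino to benzylamino change, so it serves as a guide to size only and gives no direction. No step beyond the scatter is expected, though a modest one in either direction remains possible.

The expected step is a 1.1-fold lower number from compound 3 to compound 4 (0.05 log units; within the scatter). Compound 4 is estimated at 33000 nM, with an expected range of 11000 nM to 90000 nM.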

Compound 4, concentration for 50% growth inhibition: 24800 nM
Compound 4: the middle estimate sits 1.3-fold (0.12 log units) above what was measured; low and high end bracket the measured number.
By their numbers in this assay, from the lowest: compound 2; then compounds 4 and 3 (each within the scatter of the next). At a limit, above all of these: compound 1.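

In this assay, the nitrogen on an aromatic ring now carries benzyl as well as phenyl, and the anilino to benzylamino change does not separate the two (a 1.5-fold lower number from compound 3 to compound 4 (0.18 log units; within the scatter)). Of the three groups tested at this place, only 2-methylphenyl gives a number set apart from both others, since both of its steps lie beyond the scatter (a 5.0-fold higher number from compound 2 to compound 3 (0.70 log units; beyond the scatter); a 3.3-fold higher number from compound 2 to compound 4 (0.52 log units; beyond the scatter)). Nothing available here speaks to the cause of these steps.

As far as these compounds go, whether a methyl on the ring of the benzyl group would give a step like the one from 2-methylphenyl to phenyl stays open. So does the effect of a longer chain, such as phenethyl, or of a 2-methoxyphenyl group on the same nitrogen.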